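Halogen series on the shared core of compound 2

The compounds below may be only part of what the source reports. "The series", "measured", "known", "first", "only" and "open" are said of these compounds alone.

Compound 1 `O=C(O)/C(S)=C/c1c[nH]c2ccc(I)cc12` gives 90 nM in an assay on isolated protein for inhibition of Calpain-1 catalytic subunit (Sus scrofa); a higher number here means a weaker inhibitor, a lower number a stronger inhibitor. Among the compounds with values here, compound 2 `O=C(O)/C(S)=C/c1c[nH]c2ccc(Br)cc12` gives 20 nM in this assay; the step of a 4.5-fold lower number from compound 1 to compound 2 (0.65 log units; beyond the scatter) is the only measured step. Compound 2 thus stands lowest of the two numbers, with compound 1 as its nearest neighbour. Compound 3 `O=C(O)/C(S)=C/c1c[nH]c2ccc(Cl)cc12` differs from compound 2 by chloro in place of bromo on an aromatic carbon. Within the data shown here, only the step from compound 1 to compound 2 bears on this change; it was modest, so a step of similar or smaller size, downward or within the scatter, is expected. The expected step is a 1.3-fold lower number from compound 2 to compound 3 (0.12 log units; within the scatter). Compound 3 is estimated at 15 nM, within 5 nM to 45 nM.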

Compound 3, half-maximal inhibitory concentration: 50 nM
The estimate for compound 3 lay 3.3-fold (0.52 log units) below the measured number; measured number outside the range, above it.
By their numbers in this assay, from the lowest: compound 2; then compounds 3 and 1 (each within the scatter of the next).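

With chloro in place of bromo on this aromatic carbon, the result is a 2.5-fold higher number from compound 2 to compound 3 (0.40 log units; beyond the scatter), so the earlier drop on going from iodo to bromo does not continue and bromo gives the lowest number of the three halogens. Chloro in place of iodo gives a 1.8-fold lower number from compound 1 to compound 3 (0.26 log units; within the scatter), which leaves these two halogens unseparated, while compound 2 stands clear of both. Nothing available accounts for this preference for bromo.

From the compounds shown here alone, it remains open whether fluoro or methoxy at this aromatic carbon would reach the number of compound 2, 20 nM.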